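Adding a hydroxy group to compound 2

This account rests on a few compounds, and the source may have more. Where it says the series, first, only, none or still open, it means among the compounds named here.

Of the compounds shown here, three have been measured so far. In a functional assay on ileum (Cavia porcellus) for antagonist activity, with a stated time of 30 s (a higher number here means a weaker inhibitor, a lower number a stronger inhibitor), compound 1 `O=C(O)c1cc(=O)c2cc(CCCc3ccccc3)ccc2o1` gives 3 ug/mL, compound 2 `O=C(O)c1cc(=O)c2ccc(OCCCCCOc3ccccc3)cc2o1` gives 0.4 ug/mL, and compound 3 `O=C(O)c1cc(=O)c2ccc(SCCCCCOc3ccccc3)cc2o1` gives 0.3 ug/mL. Compound 2 thus lies within the scatter of compound 3, while the number for compound 1 lies beyond the scatter from it, on the higher side.

The next compound to be tested in this assay is compound 4 `O=C(O)c1cc(=O)c2ccc(OCCCCCOc3cccc(O)c3)cc2o1`. It differs from compound 2 in one place: hydroxy in place of hydrogen on an aromatic carbon. This is hydroxy in place of hydrogen on an aromatic carbon, so the phenoxy group of compound 2 becomes 3-hydroxyphenoxy, and the rest of the structure stays the same.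

For the measured compounds named here, no two measured compounds differ in only one place, so the data offer no direct measure of what this change does, and the expectation is a cautious one. A small step towards a higher number is expected, one that stays within the scatter. The expected size of this step is a 1.5-fold higher number from compound 2 to compound 4 (0.18 log units; within the scatter). Compound 4 is estimated at 0.6 ug/mL, with an expected range from 0.2 ug/mL to 1.8 ug/mL.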

Compound 4, half-maximal inhibitory concentration: 1.5 ug/mL
The estimate for compound 4 lay 2.5-fold (0.40 log units) below the measured number; measured number inside the range.
By their numbers in this assay, from the lowest: compounds 3 and 2 (each within the scatter of the next); then compounds 4 and 1 (each within the scatter of the next).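

In this assay, hydroxy in place of hydrogen on an aromatic carbon, which turns the phenoxy group into 3-hydroxyphenoxy, gives a 3.8-fold higher number from compound 2 to compound 4 (0.57 log units; beyond the scatter), a modest step towards a weaker inhibitor. For the compounds shown here, this is the first comparison between compounds that differ in one place, and it shows that this carbon of the phenoxy ring is not indifferent to the change, since the step lies beyond the scatter. No measurement at hand accounts for the step.

The compounds shown leave open whether the step belongs to hydroxy itself or to any group at this carbon, since methoxy, fluorine or an amine here could give a similar step or a different one, and hydroxy on another carbon of the same ring might also behave differently. They also leave open whether hydroxy would give a step of similar size on compound 3, or whether a longer chain in compound 2 would change how much this ring substitution matters.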